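Sulfonyl substituent swap and liver microsomal stability

This account rests on a few compounds, and the source may have more. Where it says the series, first, only, none or still open, it means among the compounds named here.

Compound 1 `CCCCCNc1nc(Nc2ccc([N+](=O)[O-])cc2)nc(OCC(F)(F)F)n1` — 74%
Compound 2 `CC(C)OC(=O)NCCS(=O)(=O)NC(=O)c1ccc(Nc2nc(NC3(c4ccc(Cl)cc4)CC3)nc(OCC(F)(F)F)n2)cc1` — 100%
Compound 3 `O=C(NS(=O)(=O)c1ccccc1)c1ccc(Nc2nc(NC3(c4ccc(Cl)cc4)CC3)nc(OCC(F)(F)F)n2)cc1` — 100%

In an ADME assay on microsomes from liver (Homo sapiens) for metabolic stability, with a stated time of 10 min (a higher number here means that more of the compound is left, a lower number that less of the compound is left), compound 1 gives 74%, whereas compound 2 gives 100% and compound 3 gives 100%. Compound 3 thus sits level with compound 2, the two together at the top of the three numbers, and the gap from compound 3 down to compound 1 lies beyond the scatter. Within the data shown here, the only step measured so far that touches the sulfonyl substituent is no change at the digits printed from compound 2 to compound 3 (within the scatter), so a rather large exchange at that position left the read-out unchanged.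

Compound 4 `CN(C)S(=O)(=O)NC(=O)c1ccc(Nc2nc(NC3(c4ccc(Cl)cc4)CC3)nc(OCC(F)(F)F)n2)cc1` differs from compound 3 in one place: dimethylamino in place of phenyl on a sulfonyl sulfur. Among the measured compounds shown here, the one step that bears on this change is no change at the digits printed from compound 2 to compound 3 (within the scatter), which shows no movement beyond the scatter at the very same sulfonyl sulfur. On that basis no step beyond the scatter is expected for compound 4 in this assay, and the expected step is a number 4 percentage points lower from compound 3 to compound 4 (within the scatter). Compound 4 is therefore estimated to give 96% in this assay, within a range from 85% to 100%.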

Compound 4, percent of the compound remaining: 86%
Compound 4: middle estimate off by 10 percentage points, on the high side; measured number inside the range.
By their numbers in this assay, from the lowest: compound 1; then compound 4; then compounds 2 and 3 (each within the scatter of the next).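

Compound 4 shows that the sulfonyl sulfur is not a position where any exchange passes without effect in this assay: the earlier step of no change at the digits printed from compound 2 to compound 3 (within the scatter) had shown no movement, but dimethylamino in place of phenyl gives a number 14 percentage points lower from compound 3 to compound 4 (beyond the scatter) and dimethylamino in place of 2-((isopropoxycarbonyl)amino)ethyl gives a number 14 percentage points lower from compound 2 to compound 4 (beyond the scatter). Phenyl and 2-((isopropoxycarbonyl)amino)ethyl therefore stand level on this sulfur, while dimethylamino is the one of the three substituents that falls away from both, though it still stays within the top part of the scale. The change from phenyl to dimethylamino takes the group from 6 heavy atoms to 3, removes the ring and brings a nitrogen onto the sulfur, and nothing available says why the number moves.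

The compounds shown leave open which of these differences goes with the step, since all of them change together from compound 3 to compound 4. A piperidine or a morpholine on the same sulfur would keep the nitrogen and restore a ring, and a plain methyl group would keep the small size without the nitrogen.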